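The source may hold more compounds than are shown below. What is called first, only, known or untested is meant among the compounds shown, and "the series" means these compounds.

Measured compounds:
Compound 1, `CC1CC/C(=N\Nc2ccccc2Br)c2ncc(C(=O)O)c(=O)n21`, gives > 320 umol/kg in a functional assay on the whole organism for inhibition, with Rattus norvegicus as the target; on this read-out higher numbers stand for an effect only at larger amounts of compound and lower numbers for an effect already at smaller amounts; this is a limit of the assay, not a number.
Compound 2, `CC1CC/C(=N\Nc2cccc(Br)c2)c2ncc(C(=O)O)c(=O)n21`, gives > 320 umol/kg in this assay; again only a limit.
Compound 3, `CC1CC/C(=N\Nc2ccc(O)cc2)c2ncc(C(=O)O)c(=O)n21`, gives > 100 umol/kg in this assay; again only a limit.

Compound 3 therefore stands nowhere definite: every one of the three values is a limit, with one at the limit of > 100 umol/kg in this assay, at which 1 of the 3 values shown sits, and two at the limit of > 320 umol/kg in this assay, at which 2 of the 3 values shown sit, so none of the compounds can be ranked against another. Compound 4, `Cc1cccc(N/N=C2\CCC(C)n3c2ncc(C(=O)O)c3=O)c1`, has not yet been tested. It differs from compound 3 by 3-methylphenyl in place of 4-hydroxyphenyl on an amine nitrogen.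

The steps that involve the 4-hydroxyphenyl group are a step that the two limits leave unreadable from compound 1 to compound 3 and a step that the two limits leave unreadable from compound 2 to compound 3, and the step that the two limits leave unreadable from compound 1 to compound 2 is just as unreadable. Among the compounds with values here, no measured step gives a direction or a size for exchanging groups on this amine nitrogen. On that basis no step beyond the scatter is expected, and the estimated step that the limit leaves unreadable from compound 3 to compound 4 simply reflects that all three measured values are limits. Compound 4 is therefore expected to give about 400 umol/kg in this assay, with a range from 100 umol/kg to 2000 umol/kg, and most likely the assay will again report only a limit.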

Compound 4, dose for 50% inhibition: 72.5 umol/kg
Compound 4: middle estimate off by 5.5-fold (0.74 log units), on the high side; the whole stated range lies above it.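

In this assay compound 4 gives 72.5 umol/kg, the first result in this series that is a number and not a limit, so a change of the group on this amine nitrogen can now be read. Against the two bromo compounds the data give an at least 4.4-fold lower number from compound 2 to compound 4 (0.64 log units; beyond the scatter) and an at least 4.4-fold lower number from compound 1 to compound 4 (0.64 log units; beyond the scatter), while against the 4-hydroxyphenyl compound they give an at least 1.3-fold lower number from compound 3 to compound 4 (0.13 log units; that floor lies within the scatter). This last step can show no more than that because compound 3 carries only a limit: the limit of > 100 umol/kg in this assay, at which 1 of the 4 values shown sits.

On these data alone, the true size of all these steps stays open, and the steps among compound 1, compound 2 and compound 3 still cannot be read. Also open, as far as these compounds go, is whether an ethyl, methoxy or chloro group on this phenyl ring would give a number like that of compound 4.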